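Adding chloro to the phenyl of compound 2

This account rests on a few compounds, and the source may have more. Where it says the series, first, only, none or still open, it means among the compounds named here.

In a functional assay on RAW264.7 cells (Mus musculus) for inhibition, read by Griess assay, with a stated time of 20 h (a higher number here means a weaker inhibitor, a lower number a stronger inhibitor), compound 1 (`CCCCCCc1cn(-c2ccc(O)c(C(=O)NCCC)c2)nn1`) gives 19700 nM as a measured number. Compound 2 (`CCCNC(=O)c1ccc(-n2cc(-c3ccccc3)nn2)cc1O`) stands at > 20000 nM in this assay and this is a limit of the assay, not a number. The next analogue is compound 3 (`CCCNC(=O)c1ccc(-n2cc(-c3cccc(Cl)c3)nn2)cc1O`), which differs from compound 2 by the phenyl to 3-chlorophenyl change. This places chloro in place of hydrogen on an aromatic carbon, meta to a large group (chloro in place of hydrogen on an aromatic carbon). Among the compounds with values here, no measured pair shows the effect of such a change. Only a small shift toward a lower number is therefore expected in this assay, possibly none beyond the scatter. The expected step is an at least 1.2-fold lower number from compound 2 to compound 3 (0.09 log units; that floor lies within the scatter) on this estimate. For compound 3 the estimated value is 16000 nM with an expected range from 7000 nM to 35000 nM and a real chance of another limit.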

Compound 3, half-maximal inhibitory concentration: > 20000 nM
Compound 3: a limit, no number (the forecaster's own chance of this, stated with the estimate: 50%); middle value at least 1.2-fold (0.09 log units) away from the limit.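

Within the data shown here, compound 2 and compound 3 both stand at a limit of this assay, not at a number, and no step between them can be read. The compounds shown leave open whether the phenyl to 3-chlorophenyl change alters inhibition at all.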